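A few compounds are considered here, and "the series" means these few. Any claim that something is new, unique, unknown or untested is made for them only; others in the source may bear on it.

Measured compounds:
compound 1 `COc1ccc(Cl)cc1S(=O)(=O)Nc1cncc(C(=O)Nc2ccccc2)c1` — "not determined" (no result reported)
compound 2 `COc1ccc(Cl)cc1S(=O)(=O)Nc1cncc(C(N)=O)c1` — 105 nM
compound 3 `COc1ccc(Cl)cc1S(=O)(=O)Nc1cncc(C(=O)N2CCN(C)CC2)c1` — "not determined" (no result reported)

In an assay on isolated protein for inhibition of alkaline phosphatase, tissue-nonspecific isozyme (Homo sapiens) (on this read-out higher numbers stand for weaker inhibition and lower numbers for stronger inhibition), compound 2 gives 105 nM. Compound 1 and compound 3 carry no number in this assay; compound 3 thus stands nowhere on the numbers and is one of two entries without a result, leaving compound 2 as the only measured anchor of the series. Compound 4 `COc1ccc(Cl)cc1S(=O)(=O)Nc1cncc(C(=O)O)c1` differs from compound 3 in one place: hydroxy in place of 4-methylpiperazin-1-yl on a carbonyl carbon. For the measured compounds named here, no step between measured compounds exists, so the size of the change from compound 3 to compound 4 in this assay is unknown; judged only against compound 2, a weakening beyond the scatter is taken as the likelier outcome, though with wide uncertainty. Compound 4 is expected to give about 400 nM, within 60 nM to 3000 nM.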

Compound 4, half-maximal inhibitory concentration: > 20000 nM
Compound 4: a limit, no number (the forecaster's own chance of this, stated with the estimate: 25%); middle value at least 50-fold (1.69 log units) away from the limit.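

At this carbonyl carbon the exchange is far from neutral: hydroxy in place of amino gives an at least 190-fold higher number from compound 2 to compound 4 (2.27 log units; beyond the scatter) in this assay. This first readable step shows that the result depends strongly on the group carried here, at least for this pair. Compound 4 carries a limit of the assay, not a number: the limit of > 20000 nM in this assay, at which 1 of the 4 values shown sits.

Compound 1 and compound 3 carry no result, so steps involving them cannot be read and substitution on the amide nitrogen remains unresolved. As far as these compounds go, whether methoxy or methylamino on this carbonyl carbon behaves like amino or like hydroxy also stays open.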